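This account rests on a few compounds, and the source may have more. Where it says the series, first, only, none or still open, it means among the compounds named here.

Measured so far in a functional assay on aorta (Rattus norvegicus, strain Wistar) for inhibition, with a stated time of 60 min; on this read-out lower numbers stand for smaller maximal responses and higher numbers for larger maximal responses:

compound 1, `CCOc1ccccc1-c1nc2cc([N+](=O)[O-])ccc2[nH]1` — 46.4%
compound 2, `CN(C)c1ccc(-c2nc3cc(C(F)(F)F)ccc3[nH]2)cc1` — 30.9%
compound 3, `CCCOc1ccc(-c2nc3cc(C(F)(F)F)ccc3[nH]2)cc1` — 19%

Compound 3 gives the smallest largest response of the three: compound 2 stands higher, compound 1 highest, both gaps beyond the usual scatter. Compound 4, `Oc1ccc(-c2nc3cc(C(F)(F)F)ccc3[nH]2)cc1`, has not been measured yet. It differs from compound 3 in one place: hydrogen in place of propyl on an oxygen on an aromatic ring.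

Among the compounds with values here, the only measured step, a number 11.9 percentage points lower from compound 2 to compound 3 (beyond the scatter), exchanged one group on the same aromatic carbon for another and moved the response by a modest amount. Within the data shown here, no measured pair exchanges a propyl for a hydrogen on an aromatic oxygen, so no step bears directly on the change from compound 3 to compound 4. Compound 1 differs from compound 3 in several places at once and gives no clean guidance either.

Since the two measured variants at this position, compound 2 and compound 3, sit below compound 1, a moderate shift in either direction is plausible, and a move upward toward the middle of the measured range is expected, giving an estimated step of a number 13 percentage points higher from compound 3 to compound 4 (beyond the scatter) for compound 4. The estimate for compound 4 in this assay is 32%, with a range from 14% to 52%.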

Compound 4, largest response reached (Emax), in percent of the reference or control that the assay uses: 37%
Estimate against measurement, compound 4: 5 percentage points below; the range from low to high includes it.
By their numbers in this assay, from the lowest: compound 3; then compounds 2, 4 and 1 (each within the scatter of the next, the first and the last beyond it).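

In this assay, taking the propyl off the oxygen has a clear effect, a number 18 percentage points higher from compound 3 to compound 4 (beyond the scatter), so this position responds to the change from propoxy to hydroxy. Exchanging dimethylamino for hydroxy on the same aromatic carbon gives a number 6.1 percentage points higher from compound 2 to compound 4 (within the scatter), so these two groups cannot be told apart in this read-out, and among the three groups compared here, only propoxy stands apart from both others. No measurement shown here explains these differences.

With only propyl and hydrogen compared on this oxygen, the compounds shown leave open whether the response falls step by step as the chain grows, which methyl, ethyl or butyl on the same oxygen could test. Also open, as far as these compounds go, is where a primary amine or a carboxylic acid on this aromatic carbon would fall.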